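The source may report more compounds than this note shows. Statements on the series, on what has been measured and on what is new or still open speak of the compounds shown alone.

Compound 1, with the structure `Cc1c(-c2ccc(O)cc2)n(CCCOc2ccccc2)c2ccc(O)cc12`, carries a phenoxy-ended chain on the aromatic nitrogen together with a single phenolic hydroxyl on the pendant ring, and in a functional assay on MSTO-211H cells (Homo sapiens) for inhibition, read by trypan blue exclusion, with a stated time of 72 h (on this read-out lower numbers stand for stronger inhibition of growth and higher numbers for weaker inhibition of growth), compound 1 gives 2400 nM. Compound 2, with the structure `Cc1c(-c2ccc(O)c(O)c2)n(C)c2ccc(O)cc12`, keeps a methyl on the same nitrogen and bears two hydroxyls on the pendant ring. In this assay compound 2 reaches only a limit of the measurement, > 20000 nM, so no number is known for it, which is the situation described by the limit of > 20000 nM in this assay, at which 1 of the 2 values shown sits. Compound 3, with the structure `Cc1c(-c2ccc(O)c(O)c2)n(CCCOc2ccccc2)c2ccc(O)cc12`, combines the features of both: it differs from compound 2 by 2-phenoxyethyl in place of hydrogen on a saturated chain carbon bound to an aromatic nitrogen. Within the data shown here, no measured pair in this set differs only in this way, so the size of the step is open; compound 1 shows that the phenoxy chain is compatible with measurable growth inhibition, and on that ground a gain beyond the usual scatter is expected, with the step from compound 2 to compound 3 estimated at an at least 4.4-fold lower number from compound 2 to compound 3 (0.64 log units; beyond the scatter). Compound 3 is therefore expected to give about 4500 nM, within a range from 1500 nM to 16000 nM.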

Compound 3, concentration for 50% growth inhibition: 7100 nM
Beside the measured number, compound 3's estimate is 1.6-fold (0.20 log units) below it, within the range that was stated.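

In this assay the position now has a measured change: 2-phenoxyethyl in place of hydrogen on a saturated chain carbon bound to an aromatic nitrogen gives an at least 2.8-fold lower number from compound 2 to compound 3 (0.44 log units; beyond the scatter), so with two hydroxyls on the pendant ring, the chain brings growth inhibition into a measurable range. This step has only a lower bound, and its full size cannot be read because compound 2 stands at a limit and not at a number: the limit of > 20000 nM in this assay, at which 1 of the 3 values shown sits. The second step isolates the hydroxy change with the chain held constant: hydroxy in place of hydrogen on an aromatic carbon gives a 3.0-fold higher number from compound 1 to compound 3 (0.47 log units; beyond the scatter), so the added hydroxyl modestly weakens growth inhibition here.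

The compounds shown leave open whether the gain belongs to the terminal phenoxy ring or to the chain alone, a question that a plain alkyl chain, a longer chain, or a chain ending in an amine or a carboxylic acid would address. Also open, as far as these compounds go, is whether a methoxy group in place of either hydroxyl on the pendant ring would keep the growth inhibition.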